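One fluoro fewer: what compound 4 may show

The source may hold more compounds than are shown below. What is called first, only, known or untested is meant among the compounds shown, and "the series" means these compounds.

Three ureas on a shared core have been tested in an ADME assay on HEK293 cells (Homo sapiens) for cytotoxicity, with a stated time of 72 h; a higher number here means that more compound is needed for the effect, a lower number that less compound is needed. Compound 1 `Cc1cc(NC(=O)Nc2ccc(C(=O)O)cc2)c2ccccc2n1` reaches only > 25000 nM there, and this is a limit of the assay rather than a number (the limit of > 25000 nM in this assay, at which 1 of the 3 values shown sits). Compound 2 `Cc1cc(NC(=O)Nc2cc(F)ccc2F)c2ccccc2n1` gives 12000 nM in this assay, the higher of the two numbers reported, while compound 3 `Cc1cc(NC(=O)Nc2ccc(Cl)cc2Cl)c2ccccc2n1` gives 10000 nM, a value within the scatter of compound 2, so no order between the two can be claimed. Compound 4 `Cc1cc(NC(=O)Nc2cccc(F)c2)c2ccccc2n1` has not yet been measured in this assay. It differs from compound 2 as follows: hydrogen in place of fluoro on an aromatic carbon. Among the measured compounds shown here, no measured pair covers such a change, so no step beyond the scatter is expected in this assay, or at most a small rise. The expected step is a 1.3-fold higher number from compound 2 to compound 4 (0.10 log units; within the scatter). The estimate for compound 4 is 15000 nM, expected to fall between 7000 nM and 30000 nM.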

Compound 4, half-maximal effective concentration: > 25000 nM
Compound 4: a limit, no number (the forecaster's own chance of this, stated with the estimate: 25%); at least 1.6-fold (0.22 log units) between middle value and limit.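

Hydrogen in place of fluoro, on an aromatic carbon ortho to a large group and para to a fluoro group, gives the first measured step for this change: in this assay the result is an at least 2.0-fold higher number from compound 2 to compound 4 (0.31 log units; beyond the scatter). This single fluoro group therefore separates a measured number from the top of the range. Compound 4 gives a limit and not a number, so the full size of the step cannot be read: the limit of > 25000 nM in this assay, at which 2 of the 4 values shown sit.

Open, from the compounds shown here alone, is whether a methyl group, a methoxy group or an amine at this position would return a number or stay at the limit.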